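The source may hold more compounds than are shown below. What is called first, only, known or untested is meant among the compounds shown, and "the series" means these compounds.

Compound 1 `CCN(CC)CC(=O)OC1CC2(N(C)C)CC(c3ccccc3)C1C(c1ccccc1)C2` gives 30100 nM in an ADME assay on L6 cells (Rattus norvegicus) for cytotoxicity, with a stated time of 72 h; a higher number here means a weaker inhibitor, a lower number a stronger inhibitor.
Compound 2 `CCN(CC)CC(=O)OC1CC2(N3CCCCC3)CC(c3ccccc3)C1C(c1ccccc1)C2` gives 23900 nM in this assay.
Compound 3 `CN(C)C12CC(O)C(C(c3ccccc3)C1)C(c1ccccc1)C2` gives 133000 nM in this assay.

The change from compound 1 to compound 2 is piperidin-1-yl in place of dimethylamino on a saturated ring carbon. It made a 1.3-fold lower number from compound 1 to compound 2 (0.10 log units; within the scatter), so the two numbers lie within the scatter of each other and no direction can be read from them.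

Compound 4 `OC1CC2(N3CCCCC3)CC(c3ccccc3)C1C(c1ccccc1)C2` is not yet measured. From compound 3 to compound 4 the change is piperidin-1-yl in place of dimethylamino on a saturated ring carbon. The cores of compound 1 and compound 3 differ as hydrogen in place of ((diethylamino)methyl)carbonyl on an oxygen on a saturated carbon, which made a 4.4-fold higher number from compound 1 to compound 3 (0.65 log units; beyond the scatter). The surroundings of the changed place are not identical: in compound 1 the neighbouring ring atom bears a (((diethylamino)methyl)carbonyl)oxy group, in compound 3 a hydroxy group. The change is therefore the same kind of change, not the same.

For compound 4 a step of a 1.2-fold lower number from compound 3 to compound 4 (0.08 log units; within the scatter) in this assay is expected, resting on a 1.3-fold lower number from compound 1 to compound 2 (0.10 log units; within the scatter), which was within the scatter. The expected value of compound 4 is 110000 nM, estimated to fall between 50000 nM and 250000 nM.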

Compound 4, half-maximal inhibitory concentration: 37300 nM
Compound 4: middle estimate off by 2.9-fold (0.47 log units), on the high side; measured number below the stated range.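

In this assay, piperidin-1-yl in place of dimethylamino gave a 3.6-fold lower number from compound 3 to compound 4 (0.55 log units; beyond the scatter) on the core with a free hydroxy group, so the size of this step did not carry over unchanged from the core bearing the ester side chain: the same change on two cores in this assay, a 1.3-fold lower number (0.10 log units; within the scatter) from compound 1 to compound 2 and a 3.6-fold lower number (0.55 log units; beyond the scatter) from compound 3 to compound 4, 2.8-fold (0.45 log units) apart, beyond the scatter of two such steps. Hydrogen in place of ((diethylamino)methyl)carbonyl on the oxygen, read in the piperidin-1-yl compounds, gave a 1.6-fold higher number from compound 2 to compound 4 (0.19 log units; within the scatter), which also does not match the step seen with dimethylamino: the same change on two cores in this assay, a 4.4-fold higher number (0.65 log units; beyond the scatter) from compound 1 to compound 3 and a 1.6-fold higher number (0.19 log units; within the scatter) from compound 2 to compound 4, 2.8-fold (0.45 log units) apart, beyond the scatter of two such steps. Together these show that the two changes do not act independently in these four compounds, but this rests on a single set of four and does not show why the steps differ or how either change would behave on another core.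

The compounds shown leave open whether another cyclic amine on that saturated ring carbon, such as pyrrolidine or morpholine, would follow compound 3 or compound 4. They also leave open what a simple acetyl group on the oxygen would do in place of the ((diethylamino)methyl)carbonyl group.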